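Expected Clearance After Shrinking the Amide Headgroup

A few compounds are considered here, and "the series" means these few. Any claim that something is new, unique, unknown or untested is made for them only; others in the source may bear on it.

Compound 1, `C[C@@H]1CN(c2sc(C(F)(F)F)nc2-c2nc3cc(OCCO)ccc3[nH]2)CCN1C(=O)Cn1cnc2cccnc21`, gives 43 mL.min-1.g-1.
Compound 2, `C[C@@H]1CN(c2sc(C(F)(F)F)nc2-c2nc3ccccc3[nH]2)CCN1C(=O)Cn1cnc2c1CCN(C)C2`, gives 21 mL.min-1.g-1.
Compound 3, `Cc1nc(C)n(CC(=O)N2CCN(c3sc(C(F)(F)F)nc3-c3nc4ccc(C(C)(C)O)c(F)c4[nH]3)C[C@H]2C)n1`, is reported only as the limit < 10 mL.min-1.g-1; that is a boundary of the measurement, not a number.

All three were run in an ADME assay on microsomes from liver (Homo sapiens) for metabolic stability, read by LC-MS, using NADPH, with a stated time of 15 min, tested at 1 uM; on this read-out lower numbers stand for slow clearance and higher numbers for fast clearance. Among the two numbers, compound 2 holds the lower one, and the number for compound 1 lies beyond the usual scatter above it. Compound 3 sits at the limit of this assay, as noted in the limit of < 10 mL.min-1.g-1 in this assay, at which 1 of the 3 values shown sits.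

The unmeasured compound 4, `Cc1nc(C)n(CC(=O)N2CCN(c3sc(C(F)(F)F)nc3-c3nc4ccccc4[nH]3)C[C@H]2C)n1`, keeps the core of compound 2 and changes only the headgroup on the amide: a group of 7 heavy atoms (4 carbon, 3 nitrogen; one five-membered aromatic ring with 3 hetero atoms) in place of a group of 10 heavy atoms (7 carbon, 3 nitrogen; one five-membered aromatic ring with 2 hetero atoms, one six-membered non-aromatic ring with 1 hetero atom), on a saturated chain carbon bound to a carbonyl carbon. The same 3,5-dimethyl-1H-1,2,4-triazol-1-yl headgroup is present in compound 3, but compound 3 also differs elsewhere, so the headgroup change cannot be read off alone.

Within the data shown here, with no measured pair showing this change, the step in this assay is expected to be small, within the scatter, with a slight lean toward slower clearance. The estimated step from compound 2 to compound 4 is a 1.2-fold lower number from compound 2 to compound 4 (0.09 log units; within the scatter). Compound 4 is therefore expected to give about 17 mL.min-1.g-1, between 8 mL.min-1.g-1 and 40 mL.min-1.g-1.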

Compound 4, intrinsic clearance in microsomes: 30 mL.min-1.g-1
For compound 4 the middle estimate is 1.8-fold (0.25 log units) below the measured one; low and high end bracket the measured number.
By their numbers in this assay, from the lowest: compounds 2, 4 and 1 (each within the scatter of the next, the first and the last beyond it). At a limit, below all of these: compound 3.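

In this assay, placing the 3,5-dimethyl-1H-1,2,4-triazol-1-yl group on the saturated chain carbon bound to a carbonyl carbon gives a 1.4-fold higher number from compound 2 to compound 4 (0.15 log units; within the scatter). Among these compounds, this is the first direct view of a change at this place, as the earlier compounds all differed in more than one place. On the core shared by compound 2 and compound 4, the group with a six-membered non-aromatic ring can give way to this smaller triazole without moving clearance beyond the scatter, so this pair does not separate the two headgroups. Compound 3 carries the same triazole on a different core, and its value is only a limit, not a number: the limit of < 10 mL.min-1.g-1 in this assay, at which 1 of the 4 values shown sits.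

On these data alone, whether this tolerance holds on other cores remains open. So does the clearance of a headgroup carrying an amine or a carboxylic acid at this place.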